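Methoxy for chloro: the step from compound 2 to compound 4

This account rests on a few compounds, and the source may have more. Where it says the series, first, only, none or still open, it means among the compounds named here.

Values measured so far in a functional assay on MCF7 cells (Homo sapiens) for antiproliferative activity, read by MTT assay, with a stated time of 72 h (a lower number here means a stronger inhibitor, a higher number a weaker inhibitor), are:

- compound 1 `COc1cccc(N2C(=O)COc3ccc(-c4cnc(Cl)c(NS(=O)(=O)c5ccc(F)cc5)c4)cc32)c1` gives > 40000 nM (a limit)
- compound 2 `O=C1COc2ccc(-c3cnc(Cl)c(NS(=O)(=O)c4ccc(F)cc4)c3)cc2N1C1CCCCC1` gives > 40000 nM (a limit)
- compound 3 `COc1ccc(N2C(=O)COc3ccc(-c4cnc(Cl)c(NS(=O)(=O)c5ccc(F)cc5)c4)cc32)cc1` gives 36000 nM (a number)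

Compound 2 stands at > 40000 nM as a limit and not as a number. For the measured compounds named here, the series so far is marked by the limit of > 40000 nM in this assay, at which 2 of the 3 values shown sit, and little else. Compound 4 `COc1ncc(-c2ccc3c(c2)N(C2CCCCC2)C(=O)CO3)cc1NS(=O)(=O)c1ccc(F)cc1` has methoxy in place of chloro on an aromatic carbon, next to the ring nitrogen and para to a large group, and the exchange counts as methoxy in place of chloro on an aromatic carbon in full.

Going by the values given here, none of the measured steps touches this place, since all of them change the group on the amide-type nitrogen in a ring. They are a step that the two limits leave unreadable from compound 1 to compound 2 and an at least 1.1-fold lower number from compound 1 to compound 3 (0.04 log units; that floor lies within the scatter) and an at least 1.1-fold lower number from compound 2 to compound 3 (0.04 log units; that floor lies within the scatter) and give no size for this exchange. Among the compounds with values here, the expectation rests mainly on compound 3 at 36000 nM as the only number in the set, and that compound carries the same chloro. No change beyond the scatter is expected, and the data fix no direction. In this assay the expected step is an at least 1.3-fold lower number from compound 2 to compound 4 (0.12 log units; that floor lies within the scatter) on this reading. For compound 4 the estimate is 30000 nM with an expected range from 9000 nM to 60000 nM as its bounds.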

Compound 4, half-maximal inhibitory concentration: 30100 nM
Compound 4: middle estimate off by 1.0-fold (0.00 log units), on the low side, and the stated range covers the measured number.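

In this assay, for the compounds shown here, compound 4 gives 30100 nM, a measured number, and this is the first reading at the aromatic carbon next to the ring nitrogen, where all the earlier compounds carry chloro. The chloro partner with the same cyclohexyl group is recorded only as a limit: compound 2 gives > 40000 nM. The exchange of chloro for methoxy reads as an at least 1.3-fold lower number from compound 2 to compound 4 (0.12 log units; that floor lies within the scatter), so it is a floor on the step: it shows no change beyond the scatter, yet it does not rule one out, and the true size of the step stays unread: the limit of > 40000 nM in this assay, at which 2 of the 4 values shown sit.

The compounds shown leave open whether methoxy in place of chloro behaves the same way with the 3-methoxyphenyl group of compound 1 or the 4-methoxyphenyl group of compound 3, since this exchange appears here only with cyclohexyl on the amide-type nitrogen. They also leave open how other groups on this aromatic carbon would read in this assay, for example an amine, a nitrile or a longer alkoxy chain such as ethoxy, and whether any of them would give a number clearly apart from that of compound 4.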